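The compounds below may be only part of what the source reports. "The series", "measured", "known", "first", "only" and "open" are said of these compounds alone.

Measured compounds in a functional assay on DU-145 cells (Homo sapiens) for inhibition, read by WST assay, with a stated time of 3 days; a lower number here means a stronger inhibitor, a higher number a weaker inhibitor:

compound 1, `CCn1ccnc1/C=C/C(=O)/C=C/c1coc2ccccc2c1=O`: 3000 nM
compound 2, `CCCCCn1ccnc1/C=C/C(=O)/C=C/c1coc2ccccc2c1=O`: 2700 nM
compound 3, `CC(C)n1ccnc1/C=C/C(=O)/C=C/c1coc2ccccc2c1=O`: 3300 nM

Compound 3 has the highest number of the three, but the step of a 1.1-fold higher number from compound 1 to compound 3 (0.04 log units; within the scatter) and the step of a 1.2-fold higher number from compound 2 to compound 3 (0.09 log units; within the scatter) are both small, so the three compounds are not separated in this assay. The change from compound 1 to compound 2, a 1.1-fold lower number from compound 1 to compound 2 (0.05 log units; within the scatter), is likewise within the scatter; the group on the aromatic nitrogen has so far made no difference that can be read.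

Compound 4, `CCC(CC)n1ccnc1/C=C/C(=O)/C=C/c1coc2ccccc2c1=O`, is the next member. Its difference from compound 3:

pentan-3-yl in place of isopropyl on an aromatic nitrogen

All three measured steps bear on it, since each exchanges one group on the same aromatic nitrogen for another, and none moved the number beyond the scatter. A step from compound 3 to compound 4 of the same kind is therefore expected, none beyond the scatter, as a 1.1-fold lower number from compound 3 to compound 4 (0.03 log units; within the scatter). The estimate for compound 4 in this assay is 3100 nM, with a range from 1600 nM to 6500 nM.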

Compound 4, half-maximal inhibitory concentration: 5200 nM
Compound 4: the middle estimate sits 1.7-fold (0.22 log units) below what was measured, within the range that was stated.
By their numbers in this assay, from the lowest: compounds 2, 1, 3 and 4 (each within the scatter of the next).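

With pentan-3-yl on the aromatic nitrogen, the steps (a 1.6-fold higher number from compound 3 to compound 4 (0.20 log units; within the scatter)), (a 1.9-fold higher number from compound 2 to compound 4 (0.28 log units; within the scatter)) and (a 1.7-fold higher number from compound 1 to compound 4 (0.24 log units; within the scatter)) all stay within the scatter in this assay, so this change also gives no readable difference. Pentan-3-yl therefore joins ethyl, isopropyl and pentyl at this position as a group that the assay does not separate from the others, and the comparison with pentyl adds a second group of this size to the set. No separate measurement bears on this result.

The groups shown on this nitrogen are all saturated hydrocarbon groups, so it stays open whether an amine, a carboxylic acid or a phenyl ring there would move the number beyond the scatter. Going by these compounds, whether a change elsewhere on the shared core would do so also stays open.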